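The source may report more compounds than this note shows. Statements on the series, on what has been measured and on what is new or still open speak of the compounds shown alone.

Measured compounds in an assay on cells for binding affinity to metabotropic glutamate receptor 2 (Homo sapiens), read by scintillation proximity assay; a higher number here means weaker binding, a lower number tighter binding:
compound 1 `Clc1cc(-c2ccn3c(CC4CC4)nnc3c2Cl)ccc1NC1CC1` gives 6.1 nM
compound 2 `Clc1cc(-c2ccn3c(CC4CC4)nnc3c2Cl)ccc1NC1CCOCC1` gives 19.5 nM
compound 3 `O[C@H]1CC[C@H](Nc2ccc(-c3ccn4c(CC5CC5)nnc4c3Cl)cc2Cl)CC1` gives 12.7 nM

Compound 3 sits second highest of the three numbers in this assay. Its nearest neighbour is compound 2, shown as a 1.5-fold lower number from compound 2 to compound 3 (0.19 log units; within the scatter); the wider gap is a 2.1-fold higher number from compound 1 to compound 3 (0.32 log units; beyond the scatter). The measured steps of a 3.2-fold higher number from compound 1 to compound 2 (0.50 log units; beyond the scatter) and a 2.1-fold higher number from compound 1 to compound 3 (0.32 log units; beyond the scatter) all vary the substituent on the aromatic nitrogen and leave the cyclopropylmethyl chain untouched.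

Compound 4 `O[C@H]1CC[C@H](Nc2ccc(-c3ccn4c(CC(F)(F)F)nnc4c3Cl)cc2Cl)CC1` is the next compound to be measured. The change from compound 3 is trifluoromethyl in place of cyclopropyl on a saturated chain carbon bound to an aromatic carbon. Going by the values given here, none of the measured steps touches this position, so no step bears directly on it; the shared part of compounds 1 to 3 carries this chain unchanged. Among the compounds with values here, with no precedent, the expectation for the step from compound 3 to compound 4 is a 1.6-fold higher number from compound 3 to compound 4 (0.20 log units; within the scatter), a step expected to fall inside or close to the scatter, with the range kept wide. Compound 4 is therefore estimated at 20 nM in this assay, expected between 5 nM and 80 nM.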

Compound 4, dissociation constant: 10.8 nM
The estimate for compound 4 lay 1.9-fold (0.27 log units) above the measured number; low and high end bracket the measured number.
By their numbers in this assay, from the lowest: compounds 1, 4, 3 and 2 (each within the scatter of the next, the first and the last beyond it).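

In this assay, going by these compounds alone, the only step at this position so far is a 1.2-fold lower number from compound 3 to compound 4 (0.07 log units; within the scatter), so cyclopropylmethyl and 2,2,2-trifluoroethyl are not told apart when 4-hydroxycyclohexyl sits on the aromatic nitrogen. The earlier steps shown here varied only that nitrogen substituent, while this one shows that the cyclopropyl ring can give way to the ringless trifluoromethyl with no shift beyond the scatter. Nothing available accounts for the two groups reading alike.

Going by these compounds, whether the same holds with cyclopropyl or oxan-4-yl on the aromatic nitrogen stays open, since the change is seen with one nitrogen substituent only. Also open, on these data alone, is how a longer carbon chain, a methoxy group or an amine at this place would read in this assay.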